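This account rests on a few compounds, and the source may have more. Where it says the series, first, only, none or still open, it means among the compounds named here.

Working notes on the series in a functional assay on K562 cells (Homo sapiens), read by MTT assay, with a stated time of 72 h; on this read-out higher numbers stand for weaker inhibition and lower numbers for stronger inhibition.

Compound 1 `Nc1nc2c(c(-c3ccco3)cn2[C@@H]2O[C@H](CO)[C@@H](O)[C@H]2O)c(=O)[nH]1` is measured in this assay only to a limit, > 20000 nM. Compound 2 `Nc1nc2c(c(-c3cc4ccccc4o3)cn2[C@@H]2O[C@H](CO)[C@@H](O)[C@H]2O)c(=O)[nH]1` likewise reaches only a limit in this assay, > 20000 nM. The change between them, (furan-2-yl in place of 1-benzofuran-2-yl on an aromatic carbon), gives a step that the two limits leave unreadable from compound 2 to compound 1: both values sit at the limit of > 20000 nM in this assay, at which 2 of the 3 values shown sit, so the direction and size of this change cannot be read from the pair. Compound 3 `Nc1nc(N)c2c(-c3cc4ccccc4o3)cn([C@@H]3O[C@H](CO)[C@@H](O)[C@H]3O)c2n1` carries a different core from compound 2; the difference between the two cores is not broken down here. In this assay, within the data shown here, compound 3 gives 18600 nM, the only number among the three measured values.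

Compound 4 `Nc1nc(N)c2c(-c3ccco3)cn([C@@H]3O[C@H](CO)[C@@H](O)[C@H]3O)c2n1` is not yet measured in this assay. It differs from compound 3 by furan-2-yl in place of 1-benzofuran-2-yl on an aromatic carbon, the same change as that made from compound 2 to compound 1, at a place described in the same words. The earlier instance of the change is unreadable, so no direction can be carried over from it. Because compound 3 stands at 18600 nM, a step of a 1.3-fold higher number from compound 3 to compound 4 (0.13 log units; within the scatter) is expected. Given (the limit of > 20000 nM in this assay, at which 2 of the 3 values shown sit), there is a fair chance that this assay again returns only a limit for compound 4. Compound 4 is estimated at 25000 nM in this assay, with a likely range from 9000 nM to 70000 nM.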

Compound 4, half-maximal inhibitory concentration: > 20000 nM
Compound 4 ended at the assay's limit (the forecaster's own chance of this, stated with the estimate: 60%); the middle value does not contradict the limit.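

In this assay, furan-2-yl in place of 1-benzofuran-2-yl on an aromatic carbon of the core of compound 3 gives an at least 1.0-fold higher number from compound 3 to compound 4 (0.03 log units; that floor lies within the scatter), which is a floor and not a size, as compound 4 is recorded only as a limit. The same change on the core of compound 2 cannot be read, as both members of that pair are limits, so there is no second readable size to set beside this floor, and the notes show neither that the change carries from one core to the other nor that it fails to. Compound 1 and compound 4, both with furan-2-yl, end at the limit, but so does compound 2 with 1-benzofuran-2-yl, so the limit does not separate the two groups: the limit of > 20000 nM in this assay, at which 3 of the 4 values shown sit.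

The compounds shown leave open whether another group on the same aromatic carbon, such as an amine, a carboxylic acid or a longer alkyl chain, would give a number clear of the limit on either core. They also leave open what would follow from replacing the 3,4-dihydroxy-5-(hydroxymethyl)oxolan-2-yl group, which all four compounds share, for instance with a simple methyl group.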